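Efficacy of an Amide Variant with a Constrained Linker

The source may hold more compounds than are shown below. What is called first, only, known or untested is meant among the compounds shown, and "the series" means these compounds.

Compound 2 `O=C(CCc1ccc(NCc2cccc(Oc3ccccc3)c2)cc1)N1CCCC1` holds the lower of the two efficacies measured so far in a functional assay on CHO cells for agonist activity at Free fatty acid receptor 1 (Homo sapiens), read by a luciferase reporter (on this read-out lower numbers stand for smaller maximal responses and higher numbers for larger maximal responses), giving 46%, whereas compound 1 `NC(=O)CCc1ccc(NCc2cccc(Oc3ccccc3)c2)cc1` gives 68%. Among the measured compounds shown here, the only measured step, a number 22 percentage points lower from compound 1 to compound 2 (beyond the scatter), shows that replacing the amino group with pyrrolidin-1-yl on the carbonyl carbon lowers the maximal response by a modest but real margin. Compound 3 `CC(C)NC(=O)[C@H]1C[C@@H]1c1ccc(NCc2cccc(Oc3ccccc3)c2)cc1` is made from compound 2 by 2-(isopropylcarbamoyl)cyclopropyl in place of 2-((pyrrolidin-1-yl)carbonyl)ethyl on an aromatic carbon, on an aromatic carbon para to a large group. For the measured compounds named here, the entering group brings back one hydrogen-bond donor, which compound 2 lacks and compound 1 has, so the measured step bears on this change, although the three-membered ring has no precedent here. The response of compound 3 is therefore expected to lie around 65%, with a range from 40% to 90%, an estimated step of a number 19 percentage points higher from compound 2 to compound 3 (beyond the scatter) upward in this assay.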

Compound 3, largest response reached (reported as percent of maximum), in percent of the reference or control that the assay uses: 62%
Beside the measured number, compound 3's estimate is 3 percentage points above it, and the stated range covers the measured number.
By their numbers in this assay, from the lowest: compound 2; then compounds 3 and 1 (each within the scatter of the next).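

At this aromatic carbon, in this assay, 2-(isopropylcarbamoyl)cyclopropyl in place of 2-((pyrrolidin-1-yl)carbonyl)ethyl gives a number 16 percentage points higher from compound 2 to compound 3 (beyond the scatter), so a group of equal heavy-atom count, with a three-membered ring of carbon only and 2 defined stereocentres, is accepted here. Set against 2-carbamoylethyl, the same group gives a number 6 percentage points lower from compound 1 to compound 3 (within the scatter), so this read-out does not separate the two. No measurement at hand offers a reason for the rise.

On these data alone, the ring and the amide hydrogen change together in the step to compound 3, so the share of each in the higher response stays open. As far as these compounds go, it is also open how the maximal response would respond to a carboxylic acid in place of the amide, or to a longer chain in place of the cyclopropyl ring.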